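This account rests on a few compounds, and the source may have more. Where it says the series, first, only, none or still open, it means among the compounds named here.

In a physicochemical assay for lipophilicity, at pH 3 (on this read-out lower numbers stand for lower lipophilicity and higher numbers for higher lipophilicity), compound 1 `Cc1ccc2c(NCc3ccco3)nc(NC(C)C)nc2c1` gives 1.58. Compound 3 `COc1ccc2c(NCc3ccco3)nc(NC(C)C)nc2c1`, which carries methoxy in place of methyl on an aromatic carbon, gives in this assay 3.11, so the step of a number 1.53 log units higher from compound 1 to compound 3 (beyond the scatter) is a large one. Compound 2 `Cc1cccc2nc(NC(C)C)nc(NCc3ccco3)c12` gives 2.44; the difference between its core and that of compound 1 is not broken down here. Compound 4 `COc1cccc2nc(NC(C)C)nc(NCc3ccco3)c12` differs from compound 2 by methoxy in place of methyl on an aromatic carbon. This is the same kind of change as from compound 1 to compound 3, not the same: there the group sat meta to a fused ring and para to a fused ring, here it sits ortho to a fused ring and meta to a fused ring. Resting on the step of a number 1.53 log units higher from compound 1 to compound 3 (beyond the scatter), the change from compound 2 to compound 4 is expected to give a number 1.26 log units higher from compound 2 to compound 4 (beyond the scatter). Compound 4 is therefore estimated at 3.7, between 2.9 and 4.5.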

Compound 4, distribution coefficient: 2.53
Beside the measured number, compound 4's estimate is 1.17 log units above it; the whole stated range lies above it.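

In this assay the replacement of methyl by methoxy on an aromatic carbon gives a number 1.53 log units higher from compound 1 to compound 3 (beyond the scatter) on the first core but a number 0.09 log units higher from compound 2 to compound 4 (within the scatter) on the second, so the size of the step does not carry over between these two cores. For the compounds shown here, this rests on only two pairs, in which the core and the place of the group differ together, so it does not show which of these two matters or how the change would behave on any other core. Nothing given here accounts for the difference between the steps.

On these data alone, whether an amine or a carboxylic acid on the same aromatic carbon would follow either step stays open. So does what ethoxy, a longer chain than methoxy, would give on each core.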